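The compounds below may be only part of what the source reports. "The series", "measured", "known", "first", "only" and "open" are said of these compounds alone.

Measured compounds:
compound 1 `CC(C)C(=O)Nc1nc(CN=C=S)cs1` — 8200 nM
compound 2 `CC(C)(C)C(=O)Nc1nc(CN=C=S)cs1` — 4300 nM
compound 3 `CC(C)C(=O)Nc1nc(CN=C=S)c[se]1` — 28000 nM

All values come from a functional assay on L1210 cells (Mus musculus) for antiproliferative activity; on this read-out lower numbers stand for stronger inhibition and higher numbers for weaker inhibition. Compound 2 differs from compound 1 by methyl in place of hydrogen on a saturated chain carbon bound to a carbonyl carbon and two saturated chain carbons, and that change made a 1.9-fold lower number from compound 1 to compound 2 (0.28 log units; within the scatter). Compound 3 carries a different core; the difference between the two cores is not broken down here, but in this assay compound 3 stands highest of the three numbers, beyond the scatter from both compound 1 and compound 2.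

Compound 4 `CC(C)(C)C(=O)Nc1nc(CN=C=S)c[se]1` is not yet measured. It differs from compound 3 by methyl in place of hydrogen on a saturated chain carbon bound to a carbonyl carbon and two saturated chain carbons, the same change already made from compound 1 to compound 2. Because that earlier change gave a 1.9-fold lower number from compound 1 to compound 2 (0.28 log units; within the scatter), a step of similar size is expected here, a 1.9-fold lower number from compound 3 to compound 4 (0.27 log units; within the scatter), with the same caution that such a step lies within the scatter. For compound 4 in this assay the expected value is 15000 nM, estimated to fall between 7000 nM and 35000 nM.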

Compound 4, half-maximal inhibitory concentration: 18000 nM
The estimate for compound 4 lay 1.2-fold (0.08 log units) below the measured number, and the stated range covers the measured number.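

Replacing isopropyl with tert-butyl in this assay gives a 1.6-fold lower number from compound 3 to compound 4 (0.19 log units; within the scatter) and agrees with the earlier step on the other core: the same change on two cores in this assay, a 1.9-fold lower number (0.28 log units; within the scatter) from compound 1 to compound 2 and a 1.6-fold lower number (0.19 log units; within the scatter) from compound 3 to compound 4, 1.2-fold (0.09 log units) apart, within the scatter of two such steps. On these two cores, the change therefore carries over with no detectable difference in step size. This does not show that the change itself moves the number, as each step lies within the scatter, and two cores support no rule for the wider series.

Still open, as far as these compounds go, is how either core responds when a longer chain or an amine takes the place of isopropyl or tert-butyl. A third core also remains to be compared for the same change.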